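One added carbon on a stable series

A few compounds are considered here, and "the series" means these few. Any claim that something is new, unique, unknown or untested is made for them only; others in the source may bear on it.

compound 1 `CCN(Cc1ccc(OCCN2C(=O)CCC2=O)c(C)c1)C(CC(=O)O)c1ccc(Cl)cc1` gives 88%
compound 2 `Cc1cc(CN(C)C(CC(=O)O)c2ccc(Cl)cc2)ccc1OCCn1c(=O)ccn(C)c1=O` gives 68%

In an ADME assay on liver (Mus musculus) for metabolic stability, read by LC-MS, using microsomes and NADPH (on this read-out lower numbers stand for a less stable compound and higher numbers for a more stable compound), compound 2 stands at 68% and is the lower of the two, under compound 1 by a gap beyond the usual scatter. Compound 3 `CCN(Cc1ccc(OCCn2c(=O)ccn(C)c2=O)c(C)c1)C(CC(=O)O)c1ccc(Cl)cc1` differs from compound 2 in one place (methyl in place of hydrogen on a saturated chain carbon bound to an amine nitrogen) with methyl in place of hydrogen on a saturated chain carbon bound to an amine nitrogen, so that methyl becomes ethyl. For the measured compounds named here, no two measured compounds differ in one place only, so the data give no direct measure of such a change. The expectation therefore starts from compound 2 at 68% and assumes no shift beyond the scatter in this assay for this change. The expected change is a number 2 percentage points lower from compound 2 to compound 3 (within the scatter) and thus a slight fall at most. For compound 3 the estimated value is 66% with an expected range from 50% to 84% in this measurement.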

Compound 3, percent of the compound remaining: 37%
The estimate for compound 3 lay 29 percentage points above the measured number, outside the stated range (below it).
By their numbers in this assay, from the lowest: compound 3; then compound 2; then compound 1.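

In this assay, methyl in place of hydrogen on a saturated chain carbon bound to an amine nitrogen, which turns methyl into ethyl, gives a number 31 percentage points lower from compound 2 to compound 3 (beyond the scatter), so one added carbon at this place can count heavily. Ethyl alone does not force a low number, since compound 1 carries it and gives 88%, while the six-membered aromatic ring group in place of the five-membered non-aromatic ring group gives a number 51 percentage points lower from compound 1 to compound 3 (beyond the scatter). Nothing available here explains either fall.

On these data alone, it remains open whether methyl to ethyl would cost as much on a compound carrying the five-membered ring group. A propyl group at the same place also remains an open case, as the compounds shown do not say whether the number would fall further.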